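Chloro to Trifluoromethyl: Expecting a Flat Step

A few compounds are considered here, and "the series" means these few. Any claim that something is new, unique, unknown or untested is made for them only; others in the source may bear on it.

In a functional assay on HeLa cells (Homo sapiens) for antiproliferative activity, read by MTT assay, with a stated time of 72 h (on this read-out higher numbers stand for weaker inhibition and lower numbers for stronger inhibition), compound 1 `CCn1cc(C(=O)O)c(=O)c2cc(F)c(N3CCN(C(=N)NS(=O)(=O)c4ccccc4Cl)CC3)cc21` gives 32 nM. Compound 2 `N=C(NS(=O)(=O)c1ccccc1Cl)N1CCN(c2cc3c(cc2F)c(=O)c(C(=O)O)cn3C2CC2)CC1` gives 32 nM and compound 3 `N=C(NS(=O)(=O)c1ccc(C(F)(F)F)cc1)N1CCN(c2cc3c(cc2F)c(=O)c(C(=O)O)cn3C2CC2)CC1` gives 32 nM, so compound 1 stands level with both. Compound 4 `CCn1cc(C(=O)O)c(=O)c2cc(F)c(N3CCN(C(=N)NS(=O)(=O)c4ccccc4C(F)(F)F)CC3)cc21` differs from compound 1 in one place: trifluoromethyl in place of chloro on an aromatic carbon. In words, trifluoromethyl stands in place of chloro on an aromatic carbon, ortho to a large group. The nearest measured change replaced 2-chlorophenyl with 4-(trifluoromethyl)phenyl and gave no change at the digits printed from compound 2 to compound 3 (within the scatter). Swapping ethyl for cyclopropyl gave no change at the digits printed from compound 1 to compound 2 (within the scatter). Neither step left the scatter, so no step beyond the scatter is expected in this assay. The estimated step is no change at the digits printed from compound 1 to compound 4 (within the scatter). Compound 4 is expected at 32 nM, within an estimated range of 13 nM to 80 nM.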

Compound 4, half-maximal inhibitory concentration: 32 nM
Beside the measured number, compound 4's estimate shows no gap at the digits printed; the measured number falls inside the stated range.
By their numbers in this assay, from the lowest: compounds 1, 2, 3 and 4 (each within the scatter of the next).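

Here trifluoromethyl replaces chloro on an aromatic carbon, ortho to a large group, and in this assay the value holds (no change at the digits printed from compound 1 to compound 4 (within the scatter)). The earlier swap on the sulfonyl-bound phenyl changed both the group and where it sits, whereas this step changes the group alone, from 1 heavy atom to 4, and stays within the scatter. Nothing available here explains why the value holds.

Going by these compounds, whether an amine or a carboxylic acid at this same place would also leave the value level remains open.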